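This account rests on a few compounds, and the source may have more. Where it says the series, first, only, none or still open, it means among the compounds named here.

Measured compounds in a functional assay on WI-38 VA13 cells (Homo sapiens) for cytotoxicity; on this read-out higher numbers stand for an effect only at larger amounts of compound and lower numbers for an effect already at smaller amounts:
compound 1, `CCOC(=O)Nc1nc2ccc(NC(=O)c3c(Cl)cccc3Cl)cc2s1`, gives 0.0026 ug/mL
compound 2, `COc1ccc(Nc2nc3ccc(NC(=O)c4c(Cl)cccc4Cl)cc3s2)cc1`, gives 0.87 ug/mL

On this assay compound 2 holds the highest of the two numbers; its nearest neighbour is compound 1, and the step of a 330-fold higher number from compound 1 to compound 2 (2.52 log units; beyond the scatter) sets the two apart by a margin well beyond the scatter. Among the measured compounds shown here, that step exchanges the ethoxycarbonyl on the ring nitrogen for a 4-methoxyphenyl and is the only comparison measured so far.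

Compound 3, `COc1ccccc1Nc1nc2ccc(NC(=O)c3c(Cl)cccc3Cl)cc2s1`, is the next compound in the series. Relative to compound 2 the change is 2-methoxyphenyl in place of 4-methoxyphenyl on a nitrogen on an aromatic ring. The same atoms are present in both; only the place of the methoxy on the phenyl differs.

For the measured compounds named here, no measured step bears directly on this change. The step from compound 1 to compound 2 concerns a different kind of replacement on the same nitrogen and gives no guide to the direction of a move within the methoxyphenyl group. The expectation is therefore a step of a 1.1-fold higher number from compound 2 to compound 3 (0.06 log units; within the scatter) of modest size with the direction left open. For compound 3 the estimate is 1 ug/mL, with a range from 0.2 ug/mL to 5 ug/mL.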

Compound 3, half-maximal effective concentration: > 7.2 ug/mL
Compound 3 was reported as a limit; the forecaster's own chance of this, stated with the estimate: 5%; middle value at least 7.2-fold (0.85 log units) from the limit.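

In this assay, moving the methoxy on the phenyl, with the same atoms present in both compounds, gives a clear change (an at least 8.2-fold higher number from compound 2 to compound 3 (0.91 log units; beyond the scatter)), so the number at this position depends on where the substituent sits on the phenyl and not only on which kind of group the nitrogen carries. The result for compound 3 is a limit and not a number: the limit of > 7.2 ug/mL in this assay, at which 1 of the 3 values shown sits. Set against the ethoxycarbonyl, the 2-methoxyphenyl gives a wider gap than the 4-methoxyphenyl did (an at least 2700-fold higher number from compound 1 to compound 3 (3.44 log units; beyond the scatter)), and both aryl groups therefore stand well apart from the ethoxycarbonyl on this read-out.

As far as these compounds go, how far the true number for compound 3 lies past its limit remains open, and so does the full size of both steps that end at it. Also open, from the compounds shown here alone, is whether an amine or a carboxylic acid on the phenyl in place of the methoxy, or a longer chain in place of the ethyl of the ethoxycarbonyl, would give numbers closer to those of compound 1 or to those of compound 2.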